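The source may report more compounds than this note shows. Statements on the series, on what has been measured and on what is new or still open speak of the compounds shown alone.

In a functional assay on MCF7 cells (Homo sapiens) for antiproliferative activity, read by MTT assay, with a stated time of 3 days (a lower number here means a stronger inhibitor, a higher number a weaker inhibitor), compound 1 (`O=C1c2ccccc2C(=O)N1C/C=C\Cn1cc(C#Cc2ccc(Br)cc2)c(=O)[nH]c1=O`) gives > 100000 nM as a limit of the assay. Compound 2 (`CCCCCc1ccc(C#Cc2cn(C/C=C\CN3C(=O)c4ccccc4C3=O)c(=O)[nH]c2=O)cc1`) gives > 100000 nM as a limit too. Where compound 2 stands comes down to the limit of > 100000 nM in this assay, at which 2 of the 2 values shown sit, and nothing finer. For the measured compounds named here, the one measured step, a step that the two limits leave unreadable from compound 1 to compound 2 with pentyl in place of bromo, offers no size to carry forward. Compound 3 (`O=C1c2ccccc2C(=O)N1C/C=C\Cn1cc(C#CCCc2ccccc2)c(=O)[nH]c1=O`) carries phenethyl in place of 4-pentylphenyl on a triple-bonded carbon. With no readable step to lean on, the expected move is a number no higher from compound 2 to compound 3 (the limit leaves the size open) in no set direction, nothing beyond the scatter. Compound 3 is estimated at 100000 nM with an expected range from 30000 nM to 200000 nM in this test.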

Compound 3, half-maximal inhibitory concentration: > 100000 nM
Compound 3 ended at the assay's limit; the forecaster's own chance of this, stated with the estimate: 80%; the middle value lies on the limit itself.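

No step can be read among compound 1, compound 2 and compound 3, since all three give only a limit, not a number: the limit of > 100000 nM in this assay, at which 3 of the 3 values shown sit. As far as these compounds go, how strongly any of them acts, and whether changing the group on the triple-bonded carbon alters that, stays open.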